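Pyrimidinyl for Aminophenyl: Expected Cytotoxicity of Compound 3

The source may hold more compounds than are shown below. What is called first, only, known or untested is meant among the compounds shown, and "the series" means these compounds.

In an ADME assay on MT4 cells (Homo sapiens) for cytotoxicity, read by MTT assay, with a stated time of 5 days (a lower number here means that less compound is tolerated, a higher number that more compound is tolerated), compound 1 `Cc1cc(C#N)cc(C)c1Oc1nc(Nc2ccc(C#N)cc2)ncc1-c1ccsc1` gives 3920 nM, while compound 2 `Cc1cc(C#N)cc(C)c1Oc1nc(Nc2ccc(C#N)cc2)ncc1-c1ccc(N)cc1` gives 310 nM. Among the compounds with values here, compound 2 therefore stands lowest of the two numbers measured so far, and its only neighbour is compound 1. Compound 3 `Cc1cc(C#N)cc(C)c1Oc1nc(Nc2ccc(C#N)cc2)ncc1-c1cncnc1` differs from compound 2 in a single place: pyrimidin-5-yl in place of 4-aminophenyl on an aromatic carbon. Within the data shown here, one measured step bears on this change, the step of a 13-fold lower number from compound 1 to compound 2 (1.10 log units; beyond the scatter), in which the 4-aminophenyl arrived and the number fell by a large margin. Compound 3 now removes that same 4-aminophenyl and puts a heteroaryl in its place, so the expected direction is back upward in this assay, though the size is uncertain because pyrimidin-5-yl itself has not been measured. For compound 3 the expected step is an 8.1-fold higher number from compound 2 to compound 3 (0.91 log units; beyond the scatter), and the estimate for compound 3 is 2500 nM, with a range from 800 nM to 8000 nM.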

Compound 3, half-maximal cytotoxic concentration: > 298000 nM
Compound 3: no number, only a limit; the forecaster's own chance of this, stated with the estimate: 10%; middle value at least 110-fold (2.07 log units) from the limit.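

In this assay, compound 3 gives > 298000 nM, which is a limit of the assay and not a number. Pyrimidin-5-yl in place of 4-aminophenyl on this aromatic carbon gives an at least 960-fold higher number from compound 2 to compound 3 (2.98 log units; beyond the scatter), and pyrimidin-5-yl in place of thiophen-3-yl gives an at least 76-fold higher number from compound 1 to compound 3 (1.88 log units; beyond the scatter). Within the data shown here, the earlier pair showed only that the number could fall with a change at this place, whereas these steps show that it can also rise far past the number of compound 1, so thiophen-3-yl does not mark the upper end here.

On these data alone, how far the number of compound 3 actually lies past its limit stays open. Also open, as far as these compounds go, is whether the two ring nitrogens of pyrimidin-5-yl matter, which a plain phenyl or a pyridin-3-yl at this place would address.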